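Inverting one ring stereocentre in a cytotoxic depsipeptide

A few compounds are considered here, and "the series" means these few. Any claim that something is new, unique, unknown or untested is made for them only; others in the source may bear on it.

Compound 1, with structure `C/C=C(\C)[C@H]1OC(=O)[C@@H](C)NC(=O)[C@H]([C@@H](C)CC)NC(=O)CN(C)C(=O)[C@@H](Cc2ccccc2)N(C)C(=O)[C@H](C)NC(=O)[C@@H](CC(C)C)OC(=O)/C(C)=C/C[C@H](O)[C@@H]1C`, gives 0.0031 nM in a functional assay on K562 cells (Homo sapiens) for cytotoxicity, read by CellTiter-Blue, with a stated time of 72 h (on this read-out higher numbers stand for weaker inhibition and lower numbers for stronger inhibition), the lowest of the three numbers measured. Compound 3, `C/C=C(\C)[C@H]1OC(=O)[C@@H](C)NC(=O)[C@H]([C@@H](C)CC)NC(=O)CN(C)C(=O)[C@@H](Cc2ccccc2)N(C)C(=O)[C@H](C)NC(=O)[C@@H](CC(C)C)OC(=O)/C(C)=C/C[C@H](OCSC)[C@@H]1C`, gives 0.0063 nM, and the change a 2.0-fold higher number from compound 1 to compound 3 (0.31 log units; beyond the scatter) is modest. Compound 2, `C/C=C(\C)[C@@H](O)[C@@H](C)[C@@H]1C/C=C(\C)C(=O)O[C@H](CC(C)C)C(=O)N[C@@H](C)C(=O)N(C)[C@H](Cc2ccccc2)C(=O)N(C)CC(=O)N[C@@H]([C@@H](C)CC)C(=O)N[C@H](C)C(=O)O1`, gives 0.012 nM, the highest of the three. Compound 4, `C/C=C(\C)[C@H]1OC(=O)[C@@H](C)NC(=O)[C@H]([C@@H](C)CC)NC(=O)CN(C)C(=O)[C@@H](Cc2ccccc2)N(C)C(=O)[C@@H](C)NC(=O)[C@@H](CC(C)C)OC(=O)/C(C)=C/C[C@H](O)[C@@H]1C`, differs from compound 1 only in configuration: the two compounds have the same atoms and bonds and differ only in configuration as drawn: 1 of 11 stereo elements differ; a stereocentre at a saturated ring carbon is drawn S in compound 1 and R in compound 4. Within the data shown here, none of the measured steps involves a change of configuration, so there is no direct guide to its effect. A loss of potency relative to compound 1 is nonetheless expected for compound 4, though its size is uncertain. Compound 4 is therefore expected to give 0.03 nM, within a range from 0.005 nM to 0.3 nM. That estimate means a step of a 9.7-fold higher number from compound 1 to compound 4 (0.99 log units; beyond the scatter).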

Compound 4, half-maximal inhibitory concentration: 584 nM
For compound 4 the middle estimate is 19000-fold (4.29 log units) below the measured one; measured number outside the range, above it.
By their numbers in this assay, from the lowest: compound 1; then compounds 3 and 2 (each within the scatter of the next); then compound 4.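

Inverting a single stereocentre at a saturated ring carbon gives a 190000-fold higher number from compound 1 to compound 4 (5.28 log units; beyond the scatter) in this assay, far more than the change on the oxygen, which gives a 2.0-fold higher number from compound 1 to compound 3 (0.31 log units; beyond the scatter). Among these compounds, the potency of compound 1 therefore depends heavily on how this one ring carbon is arranged, a dependence the earlier compounds could not reveal. The whole loss can be assigned to that carbon because nothing else changes: the fact that compounds 1 and 4 differ only in the configuration as drawn

The compounds shown leave open why this configuration matters so much. They also leave open whether a longer chain or an amine on this ring carbon would be tolerated in either configuration.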